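Amide chain: propyl to isobutyl on the shared core

This account rests on a few compounds, and the source may have more. Where it says the series, first, only, none or still open, it means among the compounds named here.

compound 1 `C=CC1=C(C(=O)NCCCCC)C(c2ccc(Cl)c(Cl)c2)OC1` — 27500 nM
compound 2 `C=CC1=C(C(=O)NCCC)C(c2ccc(Cl)c(Cl)c2)OC1` — > 100000 nM
compound 3 `C=CC1=C(C(=O)NCc2ccc(Cl)cc2)C(c2ccc(F)cc2)OC1` — > 100000 nM

In a functional assay on SW480 cells (Homo sapiens) for cytotoxicity, read by MTT assay, with a stated time of 24 h (a higher number here means a weaker inhibitor, a lower number a stronger inhibitor), compound 1 gives 27500 nM. Compound 2 reaches only the limit of this assay, > 100000 nM, which is a limit and not a number. Compound 3 likewise stops at the limit, > 100000 nM. Compound 2 thus stands at the weak end of what has been measured, sharing its position with one other compound, as seen in the limit of > 100000 nM in this assay, at which 2 of the 3 values shown sit.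

Among the compounds with values here, the only measured step that bears on the change considered here is an at least 3.6-fold higher number from compound 1 to compound 2 (0.56 log units; beyond the scatter): removing ethyl from the amide chain pushed the number up to the limit.

Compound 4 `C=CC1=C(C(=O)NCC(C)C)C(c2ccc(Cl)c(Cl)c2)OC1` is not yet measured. It differs from compound 2 by methyl in place of hydrogen on a saturated chain carbon bound to two saturated chain carbons. Within the data shown here, this restores carbon to the amide chain, now in branched form; a branched chain has no measured precedent in this set, and compound 2 sits at a limit, so the size of any drop is uncertain. The step expected from this change is an at least 1.2-fold lower number from compound 2 to compound 4 (0.09 log units; that floor lies within the scatter). For compound 4 the estimated value in this assay is 80000 nM, with an expected range from 30000 nM to 160000 nM.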

Compound 4, half-maximal inhibitory concentration: > 100000 nM
Compound 4: a limit, no number; the forecaster's own chance of this, stated with the estimate: 45%; at least 1.2-fold (0.09 log units) between middle value and limit.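

Isobutyl on the amide chain does not lift the series off the ceiling: in this assay compound 4 stops at > 100000 nM and this is a limit, not a number. Within the data shown here, the step from compound 2 cannot be read, as both of its ends are limits; the one readable step is an at least 3.6-fold higher number from compound 1 to compound 4 (0.56 log units; beyond the scatter) and it shows that the branched chain on this position does not carry the measurable effect of the pentyl chain of compound 1. Compound 1 remains the only compound shown with a number, and the limit now holds most of the set: the limit of > 100000 nM in this assay, at which 3 of the 4 values shown sit.

The compounds shown leave open whether the measurable effect depends on the straight form of the chain or on its length, which a straight butyl chain and a longer chain such as hexyl or octyl on the shared core would help separate. They also leave open how an amine or a carboxylic acid at the end of the amide chain would read against compound 1 in this assay on this core.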